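The compounds below may be only part of what the source reports. "The series", "measured", "known", "first", "only" and "open" are said of these compounds alone.

Compound 3 `COc1ccc(-c2nc(C(F)(F)F)sc2N2CCN(C(=O)Cn3cnc4cccnc43)[C@H](C)C2)cc1` carries a 4-methoxyphenyl group on its shared core. In a functional assay on CHO-K1 cells for antagonist activity at C-X-C chemokine receptor type 3 (Homo sapiens), read by FLIPR, with a stated time of 10 min (on this read-out higher numbers stand for weaker inhibition and lower numbers for stronger inhibition), compound 3 gives 13 nM. Among the three compounds measured so far, compound 3 stands second highest. Its nearest neighbour is compound 1 `C[C@@H]1CN(c2sc(C3CC3)nc2-c2nc3ccccc3[nH]2)CCN1C(=O)Cn1cnc2cccnc21`, which in this assay gives 9.7 nM; these two values lie within the usual scatter, so neither compound can be called the stronger. Compound 2 `C[C@@H]1CN(c2sc(C3COC3)nc2-c2nc3ccccc3[nH]2)CCN1C(=O)Cn1cnc2cccnc21` gives 53 nM in this assay, a number beyond the scatter from that of compound 3.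

Compound 4 `Cc1ncc(-c2nc(C(F)(F)F)sc2N2CCN(C(=O)Cn3cnc4cccnc43)[C@H](C)C2)cn1` differs from compound 3 in one place: 2-methylpyrimidin-5-yl in place of 4-methoxyphenyl on an aromatic carbon.

Within the data shown here, the only step among the measured compounds, a 5.5-fold higher number from compound 1 to compound 2 (0.74 log units; beyond the scatter), exchanges one small saturated ring for another at a different place on the core; it does not bear on the exchange of one six-membered aromatic ring for another. Among the measured compounds shown here, no measured step therefore guides the expectation for compound 4 directly. With nothing pointing clearly either way, compound 4 is expected to land near compound 3. For compound 4 the expected step is a 1.9-fold higher number from compound 3 to compound 4 (0.28 log units; within the scatter), which could fall on either side of the scatter. Compound 4 is thus estimated at 25 nM, with a range from 8 nM to 80 nM.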

Compound 4, half-maximal inhibitory concentration: 3.6 nM
Compound 4: middle estimate off by 6.9-fold (0.84 log units), on the high side, and the stated range ends above it.
By their numbers in this assay, from the lowest: compound 4; then compounds 1 and 3 (each within the scatter of the next); then compound 2.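

On an aromatic carbon of the five-membered aromatic ring, next to the ring nitrogen, the substituent affects the result in this assay: 2-methylpyrimidin-5-yl in place of 4-methoxyphenyl gives a 3.6-fold lower number from compound 3 to compound 4 (0.56 log units; beyond the scatter). Among these compounds, this is the first measured step at this position, and it shows that the position accepts a six-membered aromatic ring with 2 hetero atoms instead of one of carbon only, with no loss of inhibition and a step in the stronger direction. No measurement at hand points to a cause for this step.

The exchange alters both the ring atoms and the small group on the ring, so the compounds shown leave open which of the two changes matters, or whether both do. A 4-methylphenyl group or a 2-methoxypyrimidin-5-yl group at this place would separate the two changes, each keeping one part of compound 3 and one part of compound 4.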